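The source may report more compounds than this note shows. Statements on the series, on what has been measured and on what is new or still open speak of the compounds shown alone.

Measured compounds:
Compound 1, `C[C@H](NC(=O)c1nnn(Cc2ccc(F)cc2)c1C(F)(F)F)c1ccc(C(=O)O)cc1`: in a functional assay on CHO cells for antagonist activity at prostaglandin E2 receptor EP4 subtype (Homo sapiens), read by calcium flux, with a stated time of 15 min (on this read-out lower numbers stand for stronger inhibition and higher numbers for weaker inhibition), compound 1 gives > 10000 nM, which is a limit of the assay rather than a number.
Compound 2, `C[C@H](NC(=O)c1c(C(F)(F)F)nnn1Cc1ccc(C(F)(F)F)cc1)c1ccc(C(=O)O)cc1`: in this assay compound 2 gives 225 nM.
Compound 3, `C[C@H](NC(=O)c1c(-c2ccccc2)nnn1Cc1ccccc1)c1ccc(C(=O)O)cc1`: in this assay compound 3 gives 647 nM.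

Of the two numbers shown, compound 3 carries the higher one, and the gap to compound 2 is beyond the scatter. Compound 4, `C[C@H](NC(=O)c1c(-c2ccccc2)nnn1Cc1cccc(C(F)(F)F)c1)c1ccc(C(=O)O)cc1`, differs from compound 3 by one change, (trifluoromethyl in place of hydrogen on an aromatic carbon), trifluoromethyl in place of hydrogen on an aromatic carbon. Going by the values given here, no pair among the measured compounds differs by this change alone, so the size of the step is open. A modest move toward a lower number is expected, a 1.6-fold lower number from compound 3 to compound 4 (0.21 log units; within the scatter), and compound 4 is estimated at 400 nM, between 130 nM and 1500 nM.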

Compound 4, half-maximal inhibitory concentration: 23 nM
Beside the measured number, compound 4's estimate is 17-fold (1.24 log units) above it, and the stated range ends above it.
By their numbers in this assay, from the lowest: compound 4; then compound 2; then compound 3. At a limit, above all of these: compound 1.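

In this assay, trifluoromethyl in place of hydrogen on an aromatic carbon, turning benzyl into 3-(trifluoromethyl)benzyl, gives a 28-fold lower number from compound 3 to compound 4 (1.45 log units; beyond the scatter) as the first change read in one place alone. Going by these compounds alone, this shows that a single substitution on this ring can move the number by a large step, a sensitivity the earlier compounds, which differ in more than one place, could not show. Nothing at hand accounts for the size of this step. The compounds shown leave open whether chlorine or a methoxy group on the same carbon would give a similar step, and whether trifluoromethyl on another carbon of that ring would.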